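Shared core series: amide end exchanged for 4-methylpiperidin-1-yl

The source may hold more compounds than are shown below. What is called first, only, known or untested is meant among the compounds shown, and "the series" means these compounds.

Compound 1 `CN(Cc1cccc(F)c1)C(=O)CCCNC(=O)c1ccc(S(C)(=O)=O)c([N+](=O)[O-])c1` is measured in an assay on isolated protein for inhibition of vitamin D3 receptor (Homo sapiens), read by fluorescence polarization (on this read-out lower numbers stand for stronger inhibition and higher numbers for weaker inhibition), where compound 1 returns only a limit of > 60000 nM. Compound 2 `CS(=O)(=O)c1ccc(C(=O)NCCC(=O)N2CCc3ccccc32)cc1[N+](=O)[O-]` likewise gives a limit, > 60000 nM. Compound 3 `CS(=O)(=O)c1ccc(C(=O)NCC(=O)N2CCCCC2)cc1[N+](=O)[O-]` also sits at a limit, > 60000 nM. Hence the limit of > 60000 nM in this assay, at which 3 of the 3 values shown sit: no compound of the series has a numeric value, and compound 1 cannot be placed relative to the others beyond sharing that limit. Among the compounds with values here, no step between measured compounds can be computed.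

Compound 4 `CC1CCN(C(=O)CCCNC(=O)c2ccc(S(C)(=O)=O)c([N+](=O)[O-])c2)CC1` has not yet been measured. It differs from compound 1 by 4-methylpiperidin-1-yl in place of (3-fluorobenzyl)(methyl)amino on a carbonyl carbon. The shared core is kept; the change is confined to the group on the carbonyl carbon that sits on the saturated chain carbon. With every measured compound at a limit, the data give no direction or size of step beyond the scatter, so the expected step that the limit leaves unreadable from compound 1 to compound 4 is essentially none. Compound 4 is therefore estimated to give 80000 nM in this assay, within 30000 nM to 300000 nM, and most probably again reported only as a limit.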

Compound 4, half-maximal inhibitory concentration: > 60000 nM
Compound 4 gave a limit, no number; the forecaster's own chance of this, stated with the estimate: 85%; the middle value is on the limit's open side.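

No step can be read from compound 1 to compound 4, since both results are limits and not numbers: the limit of > 60000 nM in this assay, at which 4 of the 4 values shown sit.

The compounds shown leave open whether any group on the carbonyl carbon of the shared core would give a numeric value in this assay.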